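Working notes: from compound 2 to compound 3

The compounds below may be only part of what the source reports. "The series", "measured", "known", "first", "only" and "open" are said of these compounds alone.

Measured so far in a physicochemical assay for lipophilicity, using the shake flask method; a higher number here means a more lipophilic compound, a lower number a more polar compound
- compound 1 `CCO/N=C/c1c(N)ncnc1Oc1ccc(NC(=O)C2(C(=O)Nc3ccc(F)cc3)CC2)cc1F` gives 3.41
- compound 2 `Nc1ncnc(Oc2ccc(NC(=O)C3(C(=O)Nc4ccc(F)cc4)CC3)cc2F)c1/C=N/OCCO` gives 2.37

Compound 2 holds the lower of the two numbers, and compound 1 stands higher (3.41). Compound 3 `C#CCO/N=C/c1c(N)ncnc1Oc1ccc(NC(=O)C2(C(=O)Nc3ccc(F)cc3)CC2)cc1F` follows from compound 2 by ethynyl in place of hydroxymethyl on a saturated chain carbon bound to an oxygen. Within the data shown here, the one measured step that bears on this is the large a number 1.04 log units lower from compound 1 to compound 2 (beyond the scatter) (hydroxy in place of hydrogen). Among the measured compounds shown here, compound 3 also lacks that hydroxy, but no ethynyl compound has been measured, so only a partial return towards compound 1 is expected in this assay. An expected a number 0.73 log units higher from compound 2 to compound 3 (beyond the scatter) would be a large rise. Compound 3 is estimated at 3.1 (expected range 2.75 to 3.45).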

Compound 3, partition coefficient: 3.34
Beside the measured number, compound 3's estimate is 0.24 log units below it; the range from low to high includes it.
By their numbers in this assay, from the lowest: compound 2; then compounds 3 and 1 (each within the scatter of the next).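

In this assay, ethynyl in place of hydroxymethyl gives a number 0.97 log units higher from compound 2 to compound 3 (beyond the scatter), so a second group at this place reads well apart from the hydroxy-bearing chain. Ethynyl in place of methyl gives a number 0.07 log units lower from compound 1 to compound 3 (within the scatter), so this assay does not separate these two chain ends, and among the three compounds only compound 2 stands apart. Nothing available accounts for this result.

The compounds shown leave open how an amine, a carboxylic acid or a longer chain would read at this place. Going by these compounds, whether the same steps hold on a different core also remains open.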